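Swapping Methoxy for Acetyl on a Shared Core

A few compounds are considered here, and "the series" means these few. Any claim that something is new, unique, unknown or untested is made for them only; others in the source may bear on it.

Compound 1 `COc1ccc(NC(=O)Nc2cc(C)nc3ccccc23)cc1` is the starting point. In an ADME assay on Raji cells (Homo sapiens) for cytotoxicity, with a stated time of 72 h (a lower number here means that less compound is needed, a higher number that more compound is needed for the effect), compound 1 gives > 25000 nM, which is a limit of the assay and not a measured number. Compound 2 `COc1ccc(NC(=O)Nc2cc(C)nc3ccccc23)cc1F` carries fluoro in place of hydrogen on an aromatic carbon. In this assay compound 2 gives > 25000 nM, again a limit and not a number. Compound 3 `CSc1ccccc1NC(=O)Nc1cc(C)nc2ccccc12` is the third measured member. In this assay compound 3 gives > 25000 nM, also a limit. Going by the values given here, the only measured step, a step that the two limits leave unreadable from compound 1 to compound 2, cannot be sized: both of its ends sit at the limit. All that the measured values show is the limit of > 25000 nM in this assay, at which 3 of the 3 values shown sit.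

Compound 4 `CC(=O)c1ccc(NC(=O)Nc2cc(C)nc3ccccc23)cc1` has not yet been measured. It differs from compound 1 by acetyl in place of methoxy on an aromatic carbon. Among the compounds with values here, no measured step involves an acetyl, and the one measured step is unreadable, so no direction can be read for this change from the data. Three compounds sharing this core all sit at the limit, and compound 4 is expected to do the same. The expected step is a step that the limit leaves unreadable from compound 1 to compound 4. Compound 4 is therefore estimated at 30000 nM, with a range from 10000 nM to 100000 nM, and most likely reported only as a limit.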

Compound 4, half-maximal effective concentration: > 25000 nM
Compound 4 gave a limit, no number; the forecaster's own chance of this, stated with the estimate: 75%; the middle value does not contradict the limit.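

Going by these compounds alone, compound 1 and compound 4 both give a limit and not a number, so the swap of methoxy for acetyl yields no step that can be read. The four compounds shown share a single result: the limit of > 25000 nM in this assay, at which 4 of the 4 values shown sit.

Still open, on these data alone, is whether any change to the shared core would give a true number in this assay.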